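This account rests on a few compounds, and the source may have more. Where it says the series, first, only, none or still open, it means among the compounds named here.

The three measured compounds share one core and differ only in the group attached to the amide carbonyl carbon. Compound 3 `O=C(Nc1cccc(-c2oc3cc(-c4ccc(F)cc4)ccc3c(=O)c2O)c1)c1cc(F)cc(F)c1` carries a 3,5-difluorophenyl there; in a functional assay on A549 cells (Homo sapiens) for antiproliferative activity, read by CCK-8 assay, with a stated time of 72 h (on this read-out higher numbers stand for weaker inhibition and lower numbers for stronger inhibition), compound 3 gives 7620 nM, the highest of the three numbers. Compound 1 `O=C(Nc1cccc(-c2oc3cc(-c4ccc(F)cc4)ccc3c(=O)c2O)c1)c1ccccc1F` gives 4410 nM in this assay, and compound 2 `O=C(Nc1cccc(-c2oc3cc(-c4ccc(F)cc4)ccc3c(=O)c2O)c1)c1ccc(Cl)nc1` gives 3580 nM. The step of a 1.7-fold higher number from compound 1 to compound 3 (0.24 log units; within the scatter) stays within the scatter, while the step of a 2.1-fold higher number from compound 2 to compound 3 (0.33 log units; beyond the scatter) is modest and just beyond it.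

Compound 4 `O=C(Nc1cccc(-c2oc3cc(-c4ccc(F)cc4)ccc3c(=O)c2O)c1)c1ccc(-c2ccccc2)cc1` is the next compound, and it changes the same place: 4-phenylphenyl in place of 3,5-difluorophenyl on a carbonyl carbon. Both earlier changes at this carbonyl carbon moved the number only a little, so a similar change is expected to do the same, with no clear direction and no step beyond the scatter. The number for compound 4 is therefore estimated at 5000 nM, with a likely range from 1500 nM to 16000 nM, which means an expected step of a 1.5-fold lower number from compound 3 to compound 4 (0.18 log units; within the scatter).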

Compound 4, half-maximal inhibitory concentration: > 100000 nM
Compound 4: a limit, no number (the forecaster's own chance of this, stated with the estimate: 10%); middle value at least 20-fold (1.30 log units) away from the limit.
By their numbers in this assay, from the lowest: compounds 2, 1 and 3 (each within the scatter of the next, the first and the last beyond it). At a limit, above all of these: compound 4.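

Compound 4 has no number in this assay, only a limit: (the limit of > 100000 nM in this assay, at which 1 of the 4 values shown sits). Measured against that limit, the change at the carbonyl carbon is large from each earlier compound (an at least 13-fold higher number from compound 3 to compound 4 (1.11 log units; beyond the scatter); an at least 27-fold higher number from compound 2 to compound 4 (1.44 log units; beyond the scatter); an at least 22-fold higher number from compound 1 to compound 4 (1.35 log units; beyond the scatter)). The three groups with one six-membered aromatic ring gave numbers close together, so they did not show what 4-phenylphenyl, with its second ring, now shows: this position does not accept every aromatic group, and one replacement here can take the number far beyond the earlier range.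

The compounds shown do not tell why the number rises so sharply, or whether the second ring itself is what matters. A smaller extension of the ring, such as a 4-methylphenyl or a 4-aminophenyl group, would help to separate these possibilities.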